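The compounds below may be only part of what the source reports. "The series", "measured", "known", "first", "only" and "open" are said of these compounds alone.

Three compounds built on a shared core have each been examined in an assay on CHO cells for displacement of a labelled ligand from adenosine receptor A3 (Homo sapiens), read by scintillation counting, with a stated time of 3 h; a higher number here means a weaker inhibitor, a lower number a stronger inhibitor. Compound 1 `CCn1c(-c2ccccc2)nc2c(NC3CCCC3)ncnc21` gives 354 nM in this assay. Compound 3 `CCCn1c(-c2ccccc2)nc2c(NC3CCCCC3)ncnc21` gives 2360 nM in this assay. Compound 2 `COc1ccc(-c2nc3c(NC4CCCC4)ncnc3n2C)cc1` gives 1850 nM in this assay, which is the second highest of the three numbers: the values of compound 2 and compound 3 lie within the scatter of each other, while the number for compound 1 sits lower by a margin beyond the scatter. Compound 4 `Cc1ccc(-c2nc3c(NC4CCCC4)ncnc3n2C)cc1` has not yet been measured. It differs from compound 2 in one place: methyl in place of methoxy on an aromatic carbon. For the measured compounds named here, no pair of measured compounds differs in only this way, so no measured step for this change is available. A small step is expected in this assay, possibly a modest fall in the number, but nothing that can be separated from the scatter with confidence. Compound 4 is estimated at 1200 nM, with a range from 400 nM to 3500 nM. For compound 4 this estimate corresponds to an expected step of a 1.5-fold lower number from compound 2 to compound 4 (0.19 log units; within the scatter).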

Compound 4, inhibition constant: 480 nM
Beside the measured number, compound 4's estimate is 2.5-fold (0.40 log units) above it, and the stated range covers the measured number.
By their numbers in this assay, from the lowest: compounds 1 and 4 (each within the scatter of the next); then compounds 2 and 3 (each within the scatter of the next).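

In this assay, for the compounds shown here, the change from 4-methoxyphenyl to 4-methylphenyl gives a 3.9-fold lower number from compound 2 to compound 4 (0.59 log units; beyond the scatter) and so provides the first comparison here between compounds that differ in one place. The earlier compounds shown here could not show this, as no two of them differed only in a single group. It shows that the number responds to the group held on this aromatic carbon, para to a large group, even when only methoxy and methyl are exchanged. Nothing available explains why the number moves in this direction.

The compounds shown leave open whether this step reflects methyl itself or the departure of methoxy, a question that a chlorine atom or an ethyl group at the same place would help to address. From the compounds shown here alone, it also remains open whether the same exchange would give a similar step with a cyclohexyl group in place of the cyclopentyl group.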